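A Bulkier Amine Substituent and Cell Toxicity

This account rests on a few compounds, and the source may have more. Where it says the series, first, only, none or still open, it means among the compounds named here.

Compound 1 `CN(C)N(c1cc(C#CC(C)(C)C)sc1C(=O)O)C(=O)[C@H]1CC[C@H](C)CC1` was tested in an ADME assay on Huh-7 cells (Homo sapiens) for cytotoxicity, read by fluorescence, with a stated time of 3 days (on this read-out lower numbers stand for higher toxicity in this test and higher numbers for lower toxicity in this test), where compound 1 gives only a limit of > 44000 nM. Compound 2 `CN(c1ccncc1)N(c1cc(C#CC(C)(C)C)sc1C(=O)O)C(=O)[C@H]1CC[C@H](C)CC1` gives 36000 nM in this assay, and the step of an at least 1.2-fold lower number from compound 1 to compound 2 (0.08 log units; that floor lies within the scatter) stays within the scatter. Compound 3 `CN1CCC(N(C)N(c2cc(C#CC(C)(C)C)sc2C(=O)O)C(=O)[C@H]2CC[C@H](C)CC2)CC1` differs from compound 1 by 1-methylpiperidin-4-yl in place of methyl on an amine nitrogen. Going by the values given here, only the step from compound 1 to compound 2 bears on this change, and it stayed within the scatter, with compound 1 sitting at the limit (the limit of > 44000 nM in this assay, at which 1 of the 2 values shown sits). No step beyond the scatter is therefore expected for compound 3, which is estimated at 40000 nM, between 18000 nM and 90000 nM, a step of an at least 1.1-fold lower number from compound 1 to compound 3 (0.04 log units; that floor lies within the scatter).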

Compound 3, half-maximal cytotoxic concentration: > 44000 nM
Compound 3: only a limit was reported; the forecaster's own chance of this, stated with the estimate: 55%; at least 1.1-fold (0.04 log units) between middle value and limit.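

In this assay compound 3 gives only a limit, > 44000 nM. With 1-methylpiperidin-4-yl, a non-aromatic ring, in place of the aromatic pyridin-4-yl on this amine nitrogen, the change is an at least 1.2-fold higher number from compound 2 to compound 3 (0.08 log units; that floor lies within the scatter). The step from compound 1 to compound 3 cannot be read, as both values are limits: the limit of > 44000 nM in this assay, at which 2 of the 3 values shown sit.

From the compounds shown here alone, whether any group on this amine nitrogen can move the number beyond the scatter remains open. A morpholin-4-yl ring or a longer chain such as n-butyl in this place could help to answer that.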